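This account rests on a few compounds, and the source may have more. Where it says the series, first, only, none or still open, it means among the compounds named here.

Compound 1 `COc1cc(C=Cc2ccc3ccccc3c2)c(C(=O)O)c(OC)c1` reached only the limit > 100000 nM in an ADME assay on HepG2 cells (Homo sapiens) for cytotoxicity, read by resazurin assay, with a stated time of 24 h; a higher number here means that more compound is tolerated, a lower number that less compound is tolerated.
Compound 2 `O=C(O)c1c(O)cc(Cl)cc1CCc1ccc2ccccc2c1` gave 35000 nM in this assay.
Compound 3 `COc1cc(O)c(C(=O)O)c(CCc2ccc3ccccc3c2)c1` gave 71000 nM in this assay.

Compound 2 differs from compound 3 by chloro in place of methoxy on an aromatic carbon, and that step ran a 2.0-fold lower number from compound 3 to compound 2 (0.31 log units; beyond the scatter). Compound 4 `COc1cc(Cl)cc(C=Cc2ccc3ccccc3c2)c1C(=O)O` carries the same kind of change on compound 1, namely (chloro in place of methoxy on an aromatic carbon); around the place the surroundings differ, since in compound 4 the new group sits meta to a methoxy group where in compound 2 it sits meta to a hydroxy group. The difference between the core of compound 1 and the core of compound 3 is not broken down here. From the compounds shown here alone, compound 1 stands at the limit of > 100000 nM in this assay, at which 1 of the 3 values shown sits, so its true value is unknown. Because the earlier step ran a 2.0-fold lower number from compound 3 to compound 2 (0.31 log units; beyond the scatter), a similarly modest lowering is expected, meaning an expected step of an at least 1.2-fold lower number from compound 1 to compound 4 (0.09 log units; that floor lies within the scatter). Compound 4 is therefore expected to give 80000 nM, most likely between 35000 nM and 200000 nM.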

Compound 4, half-maximal cytotoxic concentration: 104000 nM
For compound 4 the middle estimate is 1.3-fold (0.11 log units) below the measured one; measured number inside the range.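

No new step can be read from compound 1 to compound 4, because the value of compound 1 is only a limit: the limit of > 100000 nM in this assay, at which 1 of the 4 values shown sits. The compounds shown leave open what chloro in place of methoxy does on the core of compound 1.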